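The source may hold more compounds than are shown below. What is called first, only, known or untested is meant among the compounds shown, and "the series" means these compounds.

Measured compounds in an assay on microsomes from intestine for inhibition of acyl-CoA:cholesterol acyltransferase (Oryctolagus cuniculus); a higher number here means a weaker inhibitor, a lower number a stronger inhibitor:

compound 1, `CCc1cccc(CC)c1NC(=O)NCC1(c2ccccc2)CCCC1`: 56 nM
compound 2, `CCc1cccc(C(C)C)c1NC(=O)NCC1(c2ccccc2)CCCC1`: 25 nM
compound 3, `Cc1cccc(C(C)C)c1NC(=O)NCC1(c2ccccc2)CCCCC1`: 58 nM

Compound 1 and compound 2 share one core; compound 3 sits on another, and the difference between the two cores is not broken down here. The values of compound 1 and compound 3 in this assay lie within the scatter of each other, so no order between them is claimed. Within the first core, methyl in place of hydrogen on a saturated chain carbon bound to an aromatic carbon and a saturated chain carbon gave a 2.2-fold lower number from compound 1 to compound 2 (0.35 log units; beyond the scatter).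

Compound 4, `CCc1cccc(C(C)C)c1NC(=O)NCC1(c2ccccc2)CCCCC1`, is not yet measured. It is related to compound 3 by methyl in place of hydrogen on a saturated chain carbon bound to an aromatic carbon. This is the same kind of change as that from compound 1 to compound 2, though the place is described differently: in the earlier pair the saturated chain carbon is bound to an aromatic carbon and a saturated chain carbon, in the present pair only to an aromatic carbon. The expectation rests on compound 1 going to compound 2 with a 2.2-fold lower number from compound 1 to compound 2 (0.35 log units; beyond the scatter) and on compound 3 at 58 nM. A step of a 2.1-fold lower number from compound 3 to compound 4 (0.32 log units; beyond the scatter) is expected. Compound 4 is estimated at 28 nM in this assay, between 12 nM and 65 nM.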

Compound 4, half-maximal inhibitory concentration: 20 nM
Compound 4: the middle estimate sits 1.4-fold (0.15 log units) above what was measured; the range from low to high includes it.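

In this assay, methyl in place of hydrogen on a saturated chain carbon bound to an aromatic carbon gave a 2.9-fold lower number from compound 3 to compound 4 (0.46 log units; beyond the scatter). Set beside the earlier step, the change carries from one core to the other with no difference that can be told apart: the same change on two cores in this assay, a 2.2-fold lower number (0.35 log units; beyond the scatter) from compound 1 to compound 2 and a 2.9-fold lower number (0.46 log units; beyond the scatter) from compound 3 to compound 4, 1.3-fold (0.11 log units) apart, within the scatter of two such steps. This shows that the methyl to ethyl change moves the number in the same direction and by a comparable amount on both cores, but it rests on two pairs in a single assay, so it neither extends to any further core nor explains why the number falls.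

The compounds shown leave open how far this trend runs at that place, for instance with a longer chain such as butyl, and whether it survives an amine or a carboxylic acid on that chain. They also leave open whether the change carries over to a core with a different group in place of the phenyl.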